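The source may hold more compounds than are shown below. What is called first, only, known or untested is meant among the compounds shown, and "the series" means these compounds.

Measured compounds, with their results in a functional assay on SW480 cells (Homo sapiens) for antiproliferative activity, read by sulforhodamine B assay, with a stated time of 48 h; a higher number here means a weaker inhibitor, a lower number a stronger inhibitor:

Compound 1 `COc1ccc(/C=C/C(=O)c2ccccc2-c2cccc(F)c2)cc1` gives 140 nM.
Compound 2 `COc1ccc(/C=C/C(=O)c2ccccc2-c2ccc(F)nc2)cc1` gives 330 nM.
Compound 3 `COc1ccc(/C=C/C(=O)c2ccccc2-c2cccc(F)c2)cc1OC` gives 160 nM.

All three compounds share a chalcone-type core, and they differ from one another at two places. The first difference is the aromatic group that hangs from the core. Between compound 1 and compound 2 this change is 6-fluoropyridin-3-yl in place of 3-fluorophenyl on an aromatic carbon and it made a 2.4-fold higher number from compound 1 to compound 2 (0.37 log units; beyond the scatter), a step that is beyond the usual scatter of repeated measurements, though not a large one. The second difference is a substituent on the other aromatic ring: between compound 1 and compound 3 it is methoxy in place of hydrogen on an aromatic carbon, and the resulting step, a 1.1-fold higher number from compound 1 to compound 3 (0.06 log units; within the scatter), lies within the scatter, so compound 1 and compound 3 cannot be told apart on this evidence.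

Compound 4 `COc1ccc(/C=C/C(=O)c2ccccc2-c2ccc(F)nc2)cc1OC` has not yet been measured in this assay. It carries both changes at once. Compared with compound 3 the difference is 6-fluoropyridin-3-yl in place of 3-fluorophenyl on an aromatic carbon, exactly the same change, in the same place, as the one between compound 1 and compound 2. For the measured compounds named here, since the core difference between compound 1 and compound 3 made essentially no difference in this assay, the expectation is that the pyridyl-for-phenyl swap will behave much as it did before, giving an estimated step of a 2.4-fold higher number from compound 3 to compound 4 (0.38 log units; beyond the scatter), close in size to the earlier one, because a 2.4-fold higher number from compound 1 to compound 2 (0.37 log units; beyond the scatter) is the only measured instance of this change. Compound 4 is therefore expected to give about 380 nM, most likely between 200 nM and 720 nM.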

Compound 4, half-maximal inhibitory concentration: 1300 nM
Estimate against measurement, compound 4: 3.4-fold (0.53 log units) below, outside the stated range (above it).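

In this assay, the swap of 3-fluorophenyl for 6-fluoropyridin-3-yl kept its direction but not its size once the extra methoxy was present, giving an 8.1-fold higher number from compound 3 to compound 4 (0.91 log units; beyond the scatter), and the two instances of this change clearly differ: the same change on two cores in this assay, a 2.4-fold higher number (0.37 log units; beyond the scatter) from compound 1 to compound 2 and an 8.1-fold higher number (0.91 log units; beyond the scatter) from compound 3 to compound 4, 3.4-fold (0.54 log units) apart, beyond the scatter of two such steps Read the other way, the methoxy that made no readable difference on the core of compound 1 gave a 3.9-fold higher number from compound 2 to compound 4 (0.60 log units; beyond the scatter) when the 6-fluoropyridin-3-yl group was present, and this pair of steps also differs: the same change on two cores in this assay, a 1.1-fold higher number (0.06 log units; within the scatter) from compound 1 to compound 3 and a 3.9-fold higher number (0.60 log units; beyond the scatter) from compound 2 to compound 4, 3.4-fold (0.54 log units) apart, beyond the scatter of two such steps Together, these steps show that in these four compounds the two changes do not simply add up, so the size of a step measured on one core was not a safe guide to its size on the other, but they do not show why, and they rest on a single set of four compounds, so they establish no general rule for the series.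

The compounds shown leave open whether this dependence is tied to methoxy itself or would also appear with a hydroxyl group or a chlorine atom in its place. They also leave open whether it would persist with an amine on the pyridine ring instead of the fluorine.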